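Swapping 2-methoxyethoxy for diethylamino in a level series

The source may report more compounds than this note shows. Statements on the series, on what has been measured and on what is new or still open speak of the compounds shown alone.

Compound 1 `COCCOc1cc(/C=C/c2ccc3ccccc3c2)ccc1OC` is the starting point, and in a functional assay on P388 cells (Mus musculus) for inhibition (a lower number here means a stronger inhibitor, a higher number a weaker inhibitor), compound 1 gives 2990 nM. Its double-bond isomer, compound 2 `COCCOc1cc(/C=C\c2ccc3ccccc3c2)ccc1OC`, gives 2990 nM, level with it at the digits shown. A third relative, compound 3 `Oc1ccc(/C=C/c2ccc3ccccc3c2)cc1`, gives 4060 nM, which lies within the scatter of the other two. Compound 1 therefore stands together with both, and the three numbers show no separation.

The next structure is compound 4 `CCN(CC)c1cc(/C=C/c2ccc3ccccc3c2)ccc1OC`, in which diethylamino replaces 2-methoxyethoxy on an aromatic carbon: diethylamino in place of 2-methoxyethoxy on an aromatic carbon. Among the compounds with values here, only one single-place step has been measured, no change at the digits printed from compound 1 to compound 2 (within the scatter). Its reach is limited by the fact that compounds 1 and 2 differ only in the configuration as drawn, so it gives no direct measure of exchanging this group.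

Within the data shown here, the sole guide is that compound 3 at 4060 nM remains within the scatter of compound 1 at 2990 nM, so no step beyond the scatter is expected in this assay, although this exchange is untested. The expected change is a 1.0-fold higher number from compound 1 to compound 4 (0.00 log units; within the scatter). For compound 4 the estimated value is 3000 nM. Among the measured compounds shown here, the range expected for compound 4 runs from 800 nM to 10000 nM, kept wide because no measured step covers this exchange.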

Compound 4, half-maximal inhibitory concentration: > 5000 nM
Compound 4: only a limit was reported (the forecaster's own chance of this, stated with the estimate: 10%); at least 1.6-fold (0.22 log units) between middle value and limit.
By their numbers in this assay, from the lowest: compounds 1, 2 and 3 (each within the scatter of the next). At a limit, above all of these: compound 4.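

In this assay compound 4 returns only a limit, > 5000 nM, which is a limit of the assay and not a number. Within the data shown here, the step reads an at least 1.6-fold higher number from compound 1 to compound 4 (0.22 log units; that floor lies within the scatter), so it gives only a floor, and that floor does not separate the two compounds, although it is the first measure of a group exchange at this place, on an aromatic carbon ortho to a methoxy group, where diethylamino and 2-methoxyethoxy have the same count of heavy atoms but diethylamino brings nitrogen in place of the oxygens. The earlier single-place step could not speak to this exchange because of what separated its two compounds: the fact that compounds 1 and 2 differ only in the configuration as drawn.

Going by these compounds, how far compound 4 really lies from compound 1 remains unknown, and the reading goes no further than this: the limit of > 5000 nM in this assay, at which 1 of the 4 values shown sits. Also open, on these data alone, is whether a smaller amine such as dimethylamino, a plain ethoxy chain or a carboxylic acid at the same place would give a number that could be read in this assay, and so show whether the nitrogen, the length of the chain or neither matters here.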